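Trifluoromethyl ketones: phenyl against ethyl at the chain end

The source may report more compounds than this note shows. Statements on the series, on what has been measured and on what is new or still open speak of the compounds shown alone.

Three compounds carry numbers in an assay on isolated protein for binding affinity to Fatty-acid amide hydrolase 1 (Mus musculus), read by radioligand binding and fluorescence; on this read-out lower numbers stand for stronger inhibition and higher numbers for weaker inhibition. Compound 1 `O=C(CCCCCc1ccccc1)C(F)(F)F` gives 170 nM. Compound 2 `O=C(CCCCCCCc1ccccc1)C(F)(F)F`, which carries the longer chain to the phenyl, gives 25 nM. Compound 3 `CCCCCCCC/C=C\CCCCCCCC(=O)c1ncc(-c2ccccc2)o1`, with a different ketone in place of the trifluoromethyl ketone, gives 320 nM. Compound 2 stands lowest of the three; its step to compound 1 and its step to compound 3 both lie beyond the scatter, so among these three it is the strongest inhibitor.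

Compound 4 `CCCCCCCCCC(=O)C(F)(F)F` differs from compound 2 by ethyl in place of phenyl on a saturated chain carbon, seven bonds along the chain from a carbonyl carbon. Going by the values given here, no measured pair shows this same exchange, so the size of the step has to be guessed. The phenyl at the chain end sits on the two compounds with the lowest numbers, and its loss is expected to weaken inhibition by a modest step beyond the scatter, smaller than the gap from compound 1 to compound 2. For compound 4 the expected value in this assay is 100 nM, within a range of 30 nM to 400 nM. This estimate means a step of a 4.0-fold higher number from compound 2 to compound 4 (0.60 log units; beyond the scatter).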

Compound 4, inhibition constant: 130 nM
For compound 4 the middle estimate is 1.3-fold (0.11 log units) below the measured one, within the range that was stated.
By their numbers in this assay, from the lowest: compound 2; then compounds 4, 1 and 3 (each within the scatter of the next, the first and the last beyond it).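

In this assay, going by these compounds alone, ethyl in place of phenyl on a saturated chain carbon, seven bonds along the chain from a carbonyl carbon, gives a 5.2-fold higher number from compound 2 to compound 4 (0.72 log units; beyond the scatter), the first direct reading of this exchange. The phenyl at the chain end therefore adds to inhibition at this position on this chain, but it is not required for activity: compound 4, with no ring, still gives 130 nM. No measurement at hand accounts for the size of this step.

Open, on these data alone, is whether a cyclohexyl ring, a pyridine ring, a carboxylic acid or a longer chain at the same chain end would match phenyl or fall closer to ethyl. Also open, as far as these compounds go, is whether the same exchange gives a step of similar size on the shorter chain of compound 1.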